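Series notes: methyl in place of trifluoromethyl, compound 3 to 4

This account rests on a few compounds, and the source may have more. Where it says the series, first, only, none or still open, it means among the compounds named here.

Measured so far in a functional assay on the whole organism (strain Swiss) with Mus musculus as the target, in the maximal electroshock model, with a stated time of 0.25 h, at a dose of 100 mg/kg by the intraperitoneal route; a lower number here means a weaker effect, a higher number a stronger effect of the compound at the dose given:
compound 1 `CC(C(=O)N1CCN(c2ccccc2)CC1)N1C(=O)CCC1=O` gives 50%
compound 2 `CC(C(=O)N1CCN(c2ccc(F)cc2)CC1)N1C(=O)CCC1=O` gives 75%
compound 3 `CC(C(=O)N1CCN(c2cccc(C(F)(F)F)c2)CC1)N1C(=O)CCC1=O` gives 50%

Compound 3 stands level with compound 1 at the digits printed, and the two together are the lowest of the three numbers in this assay; its nearest neighbour is compound 1, from which it is separated by no change at the digits printed from compound 1 to compound 3 (within the scatter), and its furthest is compound 2. Going by the values given here, the one step that moves the number is a number 25 percentage points higher from compound 1 to compound 2 (beyond the scatter), brought by fluoro in place of hydrogen on an aromatic carbon.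

Compound 4 `Cc1cccc(N2CCN(C(=O)C(C)N3C(=O)CCC3=O)CC2)c1` differs from compound 3 by methyl in place of trifluoromethyl on an aromatic carbon. Among the compounds with values here, no measured step exchanges methyl for any group, so the closest guide is the step into compound 3 itself: putting trifluoromethyl onto the ring of compound 1 gave no change at the digits printed from compound 1 to compound 3 (within the scatter), so a substituent at this position has not yet shifted the read-out in this assay. A smaller carbon group at the same place is therefore expected to leave the number where compound 3 sits, with no step beyond the scatter, so no change at the digits printed from compound 3 to compound 4 (within the scatter) is the expectation. Compound 4 is estimated at 50%, within 25% to 75%.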

Compound 4, a percentage reported as activity, at one dose (the size of the read-out at that dose, not a potency): 0%
Compound 4: middle estimate off by 50 percentage points, on the high side, and the stated range ends above it.
By their numbers in this assay, from the lowest: compound 4; then compounds 1 and 3 (each within the scatter of the next); then compound 2.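

In this assay, the ring carbon meta to a large group is not indifferent to what it carries: trifluoromethyl there gave no change at the digits printed from compound 1 to compound 3 (within the scatter) while methyl in place of hydrogen at the same carbon brings a number 50 percentage points lower from compound 1 to compound 4 (beyond the scatter) in the same read-out. Going by these compounds alone, the direct exchange of the two groups gives a number 50 percentage points lower from compound 3 to compound 4 (beyond the scatter) and shows that the flat step into compound 3 did not describe the position as a whole, only that one group. Set against the best number of the series, the change of 3-methylphenyl in place of 4-fluorophenyl gives a number 75 percentage points lower from compound 2 to compound 4 (beyond the scatter) and leaves compound 4 lowest of the four.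

Going by these compounds, whether the loss belongs to methyl alone remains open, and a chloro, methoxy or amine group on the same carbon, or methyl at the carbon that holds fluoro in compound 2, would separate the readings. Nothing available bears on why methyl and trifluoromethyl part so far at this position.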